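Swapping a thiophene for a hydroxylated phenyl ring

The compounds below may be only part of what the source reports. "The series", "measured", "known", "first", "only" and "open" are said of these compounds alone.

Measured in a functional assay on K562 cells (Homo sapiens) for inhibition, with a stated time of 72 h; on this read-out lower numbers stand for stronger inhibition and higher numbers for weaker inhibition:
- compound 1 `NC1CCC(Nc2nc(NCc3ccc(-c4ccco4)nc3)c3ncn(C4CCCC4)c3n2)CC1`: 67 nM
- compound 2 `NC1CCC(Nc2nc(NCc3ccc(-c4cccs4)nc3)c3ncn(C4CCCC4)c3n2)CC1`: 100 nM
- compound 3 `NC1CCC(Nc2nc(NCc3ccc(-c4ccsc4)nc3)c3ncn(C4CCCC4)c3n2)CC1`: 150 nM

Compound 3 stands level with one relative and short of the other. The step of a 1.5-fold higher number from compound 2 to compound 3 (0.18 log units; within the scatter) lies within the scatter, whereas the step of a 2.2-fold higher number from compound 1 to compound 3 (0.35 log units; beyond the scatter) is modest but beyond it.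

Compound 4 `NC1CCC(Nc2nc(NCc3ccc(-c4ccccc4O)nc3)c3ncn(C4CCCC4)c3n2)CC1` keeps the shared core and changes only the terminal ring, with 2-hydroxyphenyl in place of thiophen-3-yl on an aromatic carbon.

For the measured compounds named here, three measured steps bear on this change, and each exchanges one five-membered aromatic ring for another. The step of a 1.5-fold higher number from compound 1 to compound 2 (0.17 log units; within the scatter) stays within the scatter, as does the thiophene exchange already mentioned, and the largest of the three, a 2.2-fold higher number from compound 1 to compound 3 (0.35 log units; beyond the scatter), is modest. None of these compounds carries a six-membered ring at this place or a hydroxyl group, so the data offer only indirect guidance and no clear direction. A small step is therefore expected, most likely none beyond the scatter, with real uncertainty on both sides.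

The estimated step is a 1.3-fold lower number from compound 3 to compound 4 (0.10 log units; within the scatter).

For compound 4 the expected value is 120 nM, with an estimated range of 40 nM to 400 nM.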

Compound 4, half-maximal inhibitory concentration: 16 nM
Compound 4: the middle estimate sits 7.5-fold (0.88 log units) above what was measured; measured number below the stated range.
By their numbers in this assay, from the lowest: compound 4; then compounds 1, 2 and 3 (each within the scatter of the next, the first and the last beyond it).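

In this assay, the terminal ring at this position proves able to move the number much further than the exchanges among five-membered rings had shown: the change gives a 9.4-fold lower number from compound 3 to compound 4 (0.97 log units; beyond the scatter), and compared with the other two relatives it gives a 6.3-fold lower number from compound 2 to compound 4 (0.80 log units; beyond the scatter) and a 4.2-fold lower number from compound 1 to compound 4 (0.62 log units; beyond the scatter). Compound 4 therefore has the lowest number of the four, and this position, on an aromatic carbon next to the ring nitrogen, accepts a six-membered aromatic ring of carbon only carrying a hydroxyl group without any loss in this read-out. No measurement shown here accounts for the gain in inhibition.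

The change from compound 3 to compound 4 alters the ring and brings in the hydroxyl group in a single step, so the compounds shown cannot say how much of the step belongs to each. A plain phenyl ring would separate those two parts, and a phenyl ring carrying a methoxy group or an amine in place of the hydroxyl group would show whether the hydroxyl group itself matters.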